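Pyrrolidinone substituent swap and cytotoxicity in this series

The source may report more compounds than this note shows. Statements on the series, on what has been measured and on what is new or still open speak of the compounds shown alone.

Compound 1 `O=C(Nc1cc(F)c(F)c(F)c1)N1Cc2c(-c3ccc(F)cc3F)cnn2CC1C1CC1` gives 32100 nM in a toxicity assay on HepG2 2.2.15 cells (Homo sapiens) for cytotoxicity, read by CellTiter-Glo; on this read-out lower numbers stand for higher toxicity in this test and higher numbers for lower toxicity in this test. Compound 2 `O=C1CC(C(F)(F)F)CN1c1cnn2c1CN(C(=O)Nc1cc(F)c(F)c(F)c1)C(C1CC1)C2` gives 115000 nM, a step of a 3.6-fold higher number from compound 1 to compound 2 (0.55 log units; beyond the scatter). Compound 3 `O=C1CC(c2ncccn2)CN1c1cnn2c1CN(C(=O)Nc1cc(F)c(F)c(F)c1)C(C1CC1)C2` reaches only the limit of this assay, > 200000 nM, so its value is a floor, not a number (the limit of > 200000 nM in this assay, at which 1 of the 3 values shown sits). The step of an at least 6.2-fold higher number from compound 1 to compound 3 (0.79 log units; beyond the scatter) and the step of an at least 1.7-fold higher number from compound 2 to compound 3 (0.24 log units; that floor lies within the scatter) show compound 3 at the low-toxicity end of the numbers seen. Compound 4 `Cc1nc(C2CC(=O)N(c3cnn4c3CN(C(=O)Nc3cc(F)c(F)c(F)c3)C(C3CC3)C4)C2)no1` differs from compound 3 by 5-methyl-1,2,4-oxadiazol-3-yl in place of pyrimidin-2-yl on a saturated ring carbon. Within the data shown here, the only step at that saturated ring carbon, an at least 1.7-fold higher number from compound 2 to compound 3 (0.24 log units; that floor lies within the scatter), was within the scatter at its floor, so compound 4 is expected to stay near compound 3, with a step of an at least 1.1-fold lower number from compound 3 to compound 4 (0.04 log units; that floor lies within the scatter) estimated. Compound 4 is estimated at 180000 nM, between 70000 nM and 400000 nM.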

Compound 4, half-maximal cytotoxic concentration: > 200000 nM
Compound 4 ended at the assay's limit (the forecaster's own chance of this, stated with the estimate: 50%); at least 1.1-fold (0.04 log units) between middle value and limit.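

In this assay compound 4 stands at a limit and not at a number, as compound 3 does, so a five-membered aromatic ring on this saturated ring carbon leaves the read-out at the limit just as a six-membered one does: the limit of > 200000 nM in this assay, at which 2 of the 4 values shown sit. The change from 2,4-difluorophenyl holds up with this second pyrrolidinone, with an at least 6.2-fold higher number from compound 1 to compound 4 (0.79 log units; beyond the scatter), whereas an at least 1.7-fold higher number from compound 2 to compound 4 (0.24 log units; that floor lies within the scatter) does not separate 5-methyl-1,2,4-oxadiazol-3-yl from trifluoromethyl. The step from compound 3 to compound 4 cannot be read, since both are limits.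

Open, as far as these compounds go, is whether a dimethylamino group or a carboxylic acid on this saturated ring carbon would also reach the limit.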